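A few compounds are considered here, and "the series" means these few. Any claim that something is new, unique, unknown or untested is made for them only; others in the source may bear on it.

Measured so far, in a functional assay (blood) for inhibition, with Homo sapiens as the target; on this read-out higher numbers stand for weaker inhibition and lower numbers for stronger inhibition:
Compound 1 `CC(=O)/C(=N\O)c1ccc(Sc2cc(F)cc(C3CCOCC3)c2)cc1` gives 850 nM.
Compound 2 `COC1(c2csc(Sc3ccc4c(c3)OCC/C4=N\O)c2)CCOCC1` gives 40 nM.
Compound 3 `Fc1cc(Sc2ccc3c(c2)CC/C3=N\OCc2ccncc2)cc(C2CCOCC2)c1` gives 90 nM.

Among these three, compound 1 stands at the highest number, which on this read-out means the weakest inhibition. Compound 3 sits nearest to it, and compound 2 furthest, and both of those gaps are wide enough to count as real differences rather than noise from repeated testing.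

The next compound, compound 4 `C/C(=N\OC(=O)N(C)C)c1ccc(Sc2cc(F)cc(C3CCOCC3)c2)cc1`, has not yet been measured. It is built from compound 1 by one change: a group of 9 heavy atoms (5 carbon, 2 nitrogen, 2 oxygen; no ring) in place of a group of 6 heavy atoms (3 carbon, 1 nitrogen, 2 oxygen; no ring), on an aromatic carbon. The change sits on an aromatic carbon of a six-membered aromatic ring of carbon only, para to a large group. The group that leaves carries one hydrogen-bond donor; the group that enters carries none, while the count of hydrogen-bond acceptors stays the same.

Going by the values given here, no measured pair differs in exactly this way. Among the compounds with values here, there is no direct precedent for the size of this step. Compound 3, which also lacks a hydrogen-bond donor on its oxygen-linked chain, gives 90 nM, which is at least a sign that a donor there is not required. The step from compound 1 to compound 4 is therefore expected to be modest and toward stronger inhibition, a 2.1-fold lower number from compound 1 to compound 4 (0.33 log units; beyond the scatter), though it could fall within the scatter. For compound 4 the expected value is 400 nM, with a likely range from 100 nM to 1600 nM.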

Compound 4, half-maximal inhibitory concentration: 2610 nM
Estimate against measurement, compound 4: 6.5-fold (0.81 log units) below; the whole stated range lies below it.
By their numbers in this assay, from the lowest: compound 2; then compound 3; then compound 1; then compound 4.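

In this assay, swapping the group of 6 heavy atoms on this aromatic carbon, para to a large group, for the group of 9 heavy atoms gives a 3.1-fold higher number from compound 1 to compound 4 (0.49 log units; beyond the scatter), a real move toward weaker inhibition. Going by these compounds alone, this is the first direct reading at this position: it responds to a change in the attached group, and this particular swap, which enlarges the group and removes its one hydrogen-bond donor, costs inhibition rather than gaining it. Nothing measured here accounts for the loss, so the step stands as an observation without an explanation.

The swap alters size and donor count at once, so the two compounds cannot show which of these matters, or whether both do. A small group carrying a donor, such as an amine, or a charged one, such as a carboxylic acid, on the same carbon of the same core would begin to separate those possibilities, and the same swap on another core would show whether the step carries over.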